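The source may hold more compounds than are shown below. What is called first, only, known or untested is meant among the compounds shown, and "the series" means these compounds.

Compound 1 `CC(C)n1nc(S(=O)(=O)c2cccc3ccccc23)c2cc(N3CCN(C)CC3)ccc21`: 98%
Compound 2 `COc1cccc(S(=O)(=O)c2n[nH]c3ccc(N4CCN(C)CC4)cc23)c1`: 100%

In a functional assay on HeLa cells for antagonist activity at 5-hydroxytryptamine receptor 6 (Homo sapiens) (on this read-out higher numbers stand for larger maximal responses and lower numbers for smaller maximal responses), compound 2 gives 100%. Its nearest neighbour on this read-out is compound 1, which gives 98%, and the gap between the two lies within the usual scatter, so neither can be set above the other. Both measured compounds reach essentially the full response of the reference. For the measured compounds named here, no step between two measured compounds that differ in one place is available, so the comparison rests on the structures alone.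

Compound 3 `COc1ccc(S(=O)(=O)c2n[nH]c3ccc(N4CCN(C)CC4)cc23)cc1` is separated from compound 2 by one rearrangement of the same atoms: 4-methoxyphenyl in place of 3-methoxyphenyl on a sulfonyl sulfur. With both measured compounds already at the full response, the expectation for this step is that it brings no change beyond the scatter. The expected step is a number 3 percentage points lower from compound 2 to compound 3 (within the scatter). Compound 3 is therefore estimated to give 97%, with a likely range from 85% to 105%.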

Compound 3, largest response reached (reported as Imax), in percent of the reference or control that the assay uses: 100%
The estimate for compound 3 lay 3 percentage points below the measured number, and the stated range covers the measured number.
By their numbers in this assay, from the lowest: compounds 1, 2 and 3 (each within the scatter of the next).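

Exchanging 3-methoxyphenyl for 4-methoxyphenyl on a sulfonyl sulfur, in this assay, brings no change at the digits printed from compound 2 to compound 3 (within the scatter). Compound 1 and compound 2 differ in more than one place, so they could not show how a single change here acts; this pair shows that moving the methoxy group within the same atoms leaves the largest response where it was, and the two isomers cannot be told apart on this read-out. Nothing measured here gives a reason for this.

From the compounds shown here alone, whether a carboxylic acid, an amine or a longer chain such as butoxy in place of the methoxy group would also leave the response unchanged stays open. The compounds shown also leave open whether the two isomers would differ on a read-out other than the largest response.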